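This account rests on a few compounds, and the source may have more. Where it says the series, first, only, none or still open, it means among the compounds named here.

Measured so far in a functional assay on SK-OV-3 cells (Homo sapiens) for antiproliferative activity, read by MTT assay, with a stated time of 24 h; on this read-out lower numbers stand for stronger inhibition and higher numbers for weaker inhibition:

- compound 1 `COc1ccc(C(=O)/C=C/c2ccc(-n3ccnc3)cc2)c2c1C=CC(C)(C)O2`: 7200 nM
- compound 2 `COc1ccc(C(=O)/C=C/c2ccc3ccccc3n2)c2c1C=CC(C)(C)O2`: 2350 nM
- compound 3 `COc1ccc(C(=O)/C=C/c2ccc(OC)c(OC)c2OC)c2c1C=CC(C)(C)O2`: a limit of the assay, > 10000 nM

Compound 1 stands highest of the two numbers in this assay; the nearest, compound 2, sits lower at 2350 nM, a gap beyond the usual scatter. For compound 3 the assay gives only a limit, > 10000 nM, and no number; one of the three values shown sits at that limit (the limit of > 10000 nM in this assay, at which 1 of the 3 values shown sits).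

Compound 4 `COc1ccc(C(=O)/C=C/c2ccc(O)cc2)c2c1C=CC(C)(C)O2` is not yet measured. It differs from compound 1 in one place: hydroxy in place of 1H-imidazol-1-yl on an aromatic carbon. Going by the values given here, no step between measured compounds maps this change, so the direction is open; a step of no more than the scatter, or a modest weakening, is expected. Compound 4 is expected at 8000 nM, within 3000 nM to 20000 nM. The expected step of a 1.1-fold higher number from compound 1 to compound 4 (0.05 log units; within the scatter) is thus small and sits within the scatter.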

Compound 4, half-maximal inhibitory concentration: > 10000 nM
Compound 4 gave a limit, no number; the forecaster's own chance of this, stated with the estimate: 35%; middle value at least 1.2-fold (0.09 log units) away from the limit.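

In this assay, going by these compounds alone, hydroxy in place of 1H-imidazol-1-yl on an aromatic carbon, para to a large group, gives the first one-place step (an at least 1.3-fold higher number from compound 1 to compound 4 (0.14 log units; that floor lies within the scatter)). Compound 4 carries only a limit, so this step is a floor, and that floor does not establish a loss beyond the scatter. Compound 4 is the second compound at the limit: the limit of > 10000 nM in this assay, at which 2 of the 4 values shown sit.

On these data alone, the true size of the step stays open. So does whether an amine or a carboxylic acid at this place would give a number below the limit.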